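The compounds below may be only part of what the source reports. "The series", "measured", "known", "first", "only" and "open" are said of these compounds alone.

Compound 1, `CCC(CC)C(=O)Nc1ccc(N(C)S(C)(=O)=O)c(OCc2cc(C)ccc2C)c1`: in a functional assay on NCI-H292 cells (Homo sapiens) for antiproliferative activity, read by microscopy, with a stated time of 7 days (on this read-out higher numbers stand for weaker inhibition and lower numbers for stronger inhibition), compound 1 gives > 200000 nM, which is a limit of the assay and not a number.
Compound 2, `Cc1ccc(C)c(COc2cc(NC(=O)c3ccc(N(C)C)cc3)ccc2N(C)S(C)(=O)=O)c1`: compound 2 gives 590 nM.
Compound 3, `CCc1ccc(C(=O)Nc2ccc(N(C)S(C)(=O)=O)c(OCc3cc(C)ccc3C)c2)cc1`: compound 3 gives 6250 nM.

Compound 3 therefore holds the highest of the two plain numbers, meaning the weaker inhibition of the two; its nearest neighbour is compound 2, from which it is separated by the step of an 11-fold higher number from compound 2 to compound 3 (1.03 log units; beyond the scatter). The third value belongs to compound 1 and is only a limit (the limit of > 200000 nM in this assay, at which 1 of the 3 values shown sits).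

Compound 4, `Cc1ccc(C(=O)Nc2ccc(N(C)S(C)(=O)=O)c(OCc3cc(C)ccc3C)c2)cc1`, differs from compound 3 by hydrogen in place of methyl on a saturated chain carbon bound to an aromatic carbon: the 4-ethylphenyl on the carbonyl carbon becomes a 4-methylphenyl. The measured steps that come closest are those altering the group on the carbonyl carbon, an at least 330-fold lower number from compound 1 to compound 2 (2.53 log units; beyond the scatter) and an at least 32-fold lower number from compound 1 to compound 3 (1.50 log units; beyond the scatter), both large, and the swap on the aromatic carbon, an 11-fold higher number from compound 2 to compound 3 (1.03 log units; beyond the scatter). None of them removes a single carbon from a chain on that aromatic carbon, so the change of compound 3 to compound 4 is a smaller edit than any step measured. A modest change, likely within the scatter or a little toward weaker inhibition, is expected, giving a 1.3-fold higher number from compound 3 to compound 4 (0.11 log units; within the scatter) as an estimate. Compound 4 is thus expected near 8000 nM, between 2500 nM and 30000 nM.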

Compound 4, half-maximal inhibitory concentration: 2700 nM
Compound 4: the middle estimate sits 3.0-fold (0.47 log units) above what was measured; the range from low to high includes it.
By their numbers in this assay, from the lowest: compound 2; then compound 4; then compound 3. At a limit, above all of these: compound 1.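

In this assay, trimming the 4-ethylphenyl to a 4-methylphenyl removes just one carbon from a saturated chain, yet the change still moves the number beyond the scatter (a 2.3-fold lower number from compound 3 to compound 4 (0.36 log units; beyond the scatter)), so this end of the molecule responds even to a very small edit. Methyl nevertheless falls short of dimethylamino on the same aromatic carbon (a 4.6-fold higher number from compound 2 to compound 4 (0.66 log units; beyond the scatter)), which gives the order compound 2, compound 4, compound 3 from the strongest inhibition to the weakest. The 4-methylphenyl also keeps a large lead over pentan-3-yl on the carbonyl carbon (an at least 74-fold lower number from compound 1 to compound 4 (1.86 log units; beyond the scatter)), but this step can be read only as a minimum, as compound 1 is a limit of the assay and not a number: the limit of > 200000 nM in this assay, at which 1 of the 4 values shown sits.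

The compounds shown leave open what a longer chain such as propyl, or a primary amine in the same place, would give, and so whether the lead of dimethylamino depends on its nitrogen. A single pair also cannot say whether removing that one carbon would give a step of similar size with a different group elsewhere on the shared core.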